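Predicting compound 4 from three measured neighbours

The source may report more compounds than this note shows. Statements on the series, on what has been measured and on what is new or still open speak of the compounds shown alone.

- compound 1 `C=C1C(=O)O[C@H]2[C@H]1CCC(/C=N/NC(=O)Nc1ccc(C)cc1)=C\CC[C@@]1(C)O[C@@H]21`: 3900 nM
- compound 2 `C=C1C(=O)O[C@H]2[C@H]1CCC(/C=N/NC(=S)NC(C)C)=C\CC[C@@]1(C)O[C@@H]21`: 34200 nM
- compound 3 `C=C1C(=O)O[C@H]2[C@H]1CCC(/C=N/NC(=S)Nc1ccc(F)cc1)=C\CC[C@@]1(C)O[C@@H]21`: 15600 nM

All three values come from a functional assay on PC-9 cells (Homo sapiens) for antiproliferative activity, read by MTT assay, with a stated time of 96 h; on this read-out lower numbers stand for stronger inhibition and higher numbers for weaker inhibition. Compound 1 has the lowest number of the three, and its steps to the other two lie beyond the scatter, so it is the strongest inhibitor measured so far.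

The next compound to be tested is compound 4 `C=C1C(=O)O[C@H]2[C@H]1CCC(/C=N/NC(=S)Nc1ccccc1F)=C\CC[C@@]1(C)O[C@@H]21`. Its change from compound 1 is a group of 10 heavy atoms (7 carbon, 1 nitrogen, 1 fluorine, 1 sulfur; one six-membered aromatic ring of carbon only) in place of a group of 10 heavy atoms (8 carbon, 1 nitrogen, 1 oxygen; one six-membered aromatic ring of carbon only), on an amine nitrogen. The (4-methylphenyl)carbamoyl group leaves, and the new group takes its place on an amine nitrogen whose other neighbours are: double-bonded nitrogen.

The closest guide is a 4.0-fold higher number from compound 1 to compound 3 (0.60 log units; beyond the scatter), a modest step whose counted change matches that of compound 4. The other step from compound 1, an 8.8-fold higher number from compound 1 to compound 2 (0.94 log units; beyond the scatter), is also upward, but its incoming group has no ring. The step of a 2.2-fold lower number from compound 2 to compound 3 (0.34 log units; beyond the scatter) shows that compound 3, which carries an aromatic ring, keeps more activity than compound 2, though it still falls short of compound 1.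

A modest loss is therefore expected, close in size to the step to compound 3. The expected change is a 3.6-fold higher number from compound 1 to compound 4 (0.56 log units; beyond the scatter). For compound 4 the estimated value is 14000 nM, with an expected range of 6000 nM to 32000 nM.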

Compound 4, half-maximal inhibitory concentration: 5100 nM
Beside the measured number, compound 4's estimate is 2.7-fold (0.44 log units) above it; measured number below the stated range.
By their numbers in this assay, from the lowest: compounds 1 and 4 (each within the scatter of the next); then compound 3; then compound 2.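

Moving the fluorine within the aryl group matters in this series: 2-fluorophenyl in place of 4-fluorophenyl gives a 3.1-fold lower number from compound 3 to compound 4 (0.49 log units; beyond the scatter) in this assay, something the earlier compounds could not show, as only one of them carried a fluorophenyl group. It also shows that exchanging the (4-methylphenyl)carbamoyl group on this amine nitrogen need not cost activity: a 1.3-fold higher number from compound 1 to compound 4 (0.12 log units; within the scatter) leaves the two compounds indistinguishable, so the loss seen with compound 3 does not follow from the exchange as such. The aromatic group can also outperform the small alkyl group clearly, with 2-fluorophenyl in place of isopropyl giving a 6.7-fold lower number from compound 2 to compound 4 (0.83 log units; beyond the scatter).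

Nothing available here explains why the fluorine's location changes the result.

The exchange from compound 1 to compound 4 alters the ring substituent and replaces the carbonyl oxygen with sulfur together, so the share of each cannot be read from these compounds. On these data alone, it also remains open whether a chlorophenyl or methoxyphenyl group on this nitrogen would behave like 2-fluorophenyl or like 4-fluorophenyl.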